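This account rests on a few compounds, and the source may have more. Where it says the series, first, only, none or still open, it means among the compounds named here.

Compound 1 `CCCn1c(NC(=O)c2cc(C)nn2CC)nc2cc(C(N)=O)ccc21`: in an assay for activation of interferon regulatory factor 3 (Homo sapiens), read by a luciferase reporter, with a stated time of 20 h (a lower number here means that less compound is needed, a higher number that more compound is needed for the effect), compound 1 gives only a limit, > 100000 nM.
Compound 2 `CCCn1c(NC(=O)c2ccccn2)nc2cc(C(N)=O)cc(OC)c21`: in this assay compound 2 gives only a limit, > 100000 nM.
Compound 3 `COc1cc(C(N)=O)cc2nc(NC(=O)c3ccccn3)n(CCCNC(=O)OCc3ccccc3)c12`: in this assay compound 3 gives only a limit, > 100000 nM.

Compound 3 stands where all three measured compounds stand, at the limit of > 100000 nM in this assay, at which 3 of the 3 values shown sit. Going by the values given here, the single step among them, a step that the two limits leave unreadable from compound 2 to compound 3, cannot be sized, since both of its ends are limits. Compound 4 `COc1cc(C(N)=O)cc2nc(NC(=O)c3cccn3C)n(CCCNC(=O)OCc3ccccc3)c12` differs from compound 3 by 1-methyl-1H-pyrrol-2-yl in place of pyridin-2-yl on a carbonyl carbon. Among the compounds with values here, no measured step touches this change, and with every value a limit, neither direction nor size can be read from the data. The expectation is that compound 4 also sits at the limit in this assay. Compound 4 is estimated at 150000 nM, with a range from 50000 nM to 500000 nM. That estimate amounts to an expected step that the limit leaves unreadable from compound 3 to compound 4, none beyond the scatter.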

Compound 4, half-maximal effective concentration: > 100000 nM
Compound 4 gave a limit, no number; the forecaster's own chance of this, stated with the estimate: 85%; the middle value does not contradict the limit.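

Compound 3 and compound 4 both give only limits, so the step between them cannot be read. The compounds shown leave open which change to the shared core, if any, would give an actual number in this assay at all.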